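This account rests on a few compounds, and the source may have more. Where it says the series, first, only, none or still open, it means among the compounds named here.

Measured compounds in the series:

compound 1, `COc1cc(-c2nn(-c3cccc(NC(=O)Nc4cc(C(F)(F)F)cc(C(F)(F)F)c4)c3)cc2-c2ccncc2)ccc1Cl`, 3980 nM
compound 2, `O=C(Nc1cccc(-n2cc(-c3ccncc3)c(-c3ccc(Cl)c(O)c3)n2)c1)Nc1cc(C(F)(F)F)cc(C(F)(F)F)c1`, 5920 nM
compound 3, `COc1cc(-c2nn(-c3cccc(NC(=O)Nc4ccc(Cl)c(C(F)(F)F)c4)c3)cc2-c2ccncc2)ccc1Cl`, 5870 nM

All three were run in a functional assay on OVCAR-8 cells (Homo sapiens) for inhibition, read by sulforhodamine B assay, with a stated time of 48 h; on this read-out higher numbers stand for weaker inhibition of growth and lower numbers for stronger inhibition of growth. Compound 1 and compound 2 share one core and differ in one place: hydrogen in place of methyl on an oxygen on an aromatic ring. That change made a 1.5-fold higher number from compound 1 to compound 2 (0.17 log units; within the scatter), so the two values cannot be told apart here. Within the data shown here, compound 3 carries a different core from compound 1; the difference between the two cores is not broken down here, and no step between them is given. In this assay compound 3 gives 5870 nM, and compound 2 gives 5920 nM, the two numbers sitting within the scatter of each other.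

Not yet measured is compound 4, `O=C(Nc1cccc(-n2cc(-c3ccncc3)c(-c3ccc(Cl)c(O)c3)n2)c1)Nc1ccc(Cl)c(C(F)(F)F)c1`. Relative to compound 3 it differs in one place: hydrogen in place of methyl on an oxygen on an aromatic ring. This is the same change, at the same place, as the one from compound 1 to compound 2, and it is the only other time that change occurs among the compounds shown.

The expectation for compound 4 rests on that one precedent. Because a 1.5-fold higher number from compound 1 to compound 2 (0.17 log units; within the scatter) stayed within the scatter, the estimated step from compound 3 to compound 4 is a 1.4-fold higher number from compound 3 to compound 4 (0.13 log units; within the scatter), which again should stay within the scatter. Compound 4 is therefore expected near 8000 nM in this assay, with the likely range estimated from 4000 nM to 16000 nM. The uncertainty is wide, since the precedent is a single pair on a different core and the step itself is small.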

Compound 4, concentration for total growth inhibition: 2280 nM
Estimate against measurement, compound 4: 3.5-fold (0.55 log units) above; measured number outside the range, below it.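

In this assay, going from methoxy to hydroxy on the core of compound 3 gives a 2.6-fold lower number from compound 3 to compound 4 (0.41 log units; beyond the scatter), a modest step that lies beyond the scatter. Set beside the earlier pair, the result of this change does not carry over unchanged from one core to the other: the same change on two cores in this assay, a 1.5-fold higher number (0.17 log units; within the scatter) from compound 1 to compound 2 and a 2.6-fold lower number (0.41 log units; beyond the scatter) from compound 3 to compound 4, 3.8-fold (0.58 log units) apart, beyond the scatter of two such steps This shows that the outcome of the change depends on the core within these two pairs, but the step on the core of compound 1 lies within the scatter, so it does not establish a true reversal of direction, and two pairs give neither a reason for the gap nor a rule for any other core in the series.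

The compounds shown leave open whether the lower number for compound 4 is specific to hydroxy, since the only groups compared at this place are methoxy and hydroxy, and an ethoxy group or an amine in the same place on the core of compound 3 would help settle that. They also leave open which of the two outcomes a third core carrying the same methoxy and hydroxy pair would follow.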